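Methyl for methoxy on the amide aryl ring

A few compounds are considered here, and "the series" means these few. Any claim that something is new, unique, unknown or untested is made for them only; others in the source may bear on it.

Measured compounds:
compound 1 `COc1ccc(C(=O)Nc2cccc(-c3oc4cc(-c5ccc(F)cc5)ccc4c(=O)c3O)c2)cc1`: 16500 nM
compound 2 `O=C(Nc1cccc(-c2oc3cc(-c4ccc(F)cc4)ccc3c(=O)c2O)c1)c1ccc(C(F)(F)F)cc1`: 29400 nM
compound 3 `COc1cccc(C(=O)Nc2cccc(-c3oc4cc(-c5ccc(F)cc5)ccc4c(=O)c3O)c2)c1`: 9160 nM

All three share one core and differ only in the aryl group attached to the amide carbonyl. In a functional assay on MDA-MB-231 cells (Homo sapiens) for antiproliferative activity, read by CCK-8 assay, with a stated time of 72 h (on this read-out higher numbers stand for weaker inhibition and lower numbers for stronger inhibition), compound 3 gives 9160 nM, the lowest of the three numbers. Its nearest neighbour is compound 1 with 16500 nM, and the step of a 1.8-fold lower number from compound 1 to compound 3 (0.26 log units; within the scatter) is within the scatter. The step of a 3.2-fold lower number from compound 2 to compound 3 (0.51 log units; beyond the scatter) is beyond it, so compound 3 stands apart from compound 2 but not from compound 1.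

Compound 4 `Cc1cccc(C(=O)Nc2cccc(-c3oc4cc(-c5ccc(F)cc5)ccc4c(=O)c3O)c2)c1` is not yet measured. It differs from compound 3 by methyl in place of methoxy on an aromatic carbon, meta to a large group. Among the measured compounds shown here, no measured step changes a methoxy into a methyl; the only step touching a substituent on that ring, a 1.8-fold higher number from compound 1 to compound 2 (0.25 log units; within the scatter), swaps methoxy for trifluoromethyl at a different position and stays within the scatter. On this basis the expected step of a 1.1-fold higher number from compound 3 to compound 4 (0.04 log units; within the scatter) is estimated to be none beyond the scatter, in no clear direction.

For compound 4 the estimate in this assay is 10000 nM, with an expected range from 4000 nM to 25000 nM.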

Compound 4, half-maximal inhibitory concentration: 2840 nM
Estimate against measurement, compound 4: 3.5-fold (0.55 log units) above; the measured number lies below the stated range.
By their numbers in this assay, from the lowest: compound 4; then compounds 3, 1 and 2 (each within the scatter of the next, the first and the last beyond it).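

Going from 3-methoxyphenyl to 3-methylphenyl on the carbonyl carbon in this assay gives a 3.2-fold lower number from compound 3 to compound 4 (0.51 log units; beyond the scatter) and is the first single exchange at this position to move the number beyond the scatter while the substituent stays in the same place on the ring; the earlier steps from compound 1 left open whether any substituent at this place mattered. The same 3-methylphenyl group also separates from the other two aryl groups, with a 5.8-fold lower number from compound 1 to compound 4 (0.76 log units; beyond the scatter) and a 10-fold lower number from compound 2 to compound 4 (1.02 log units; beyond the scatter), so compound 4 has the lowest number of the four and the aryl group on the amide carbonyl now spans a large range in this series. No measurement shown here explains why the methyl group reads lower than the methoxy group.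

As far as these compounds go, this gain rests on a single pair, so it remains open whether methyl would give a similar step at another place on this ring. From the compounds shown here alone, it also remains open how an ethyl group, a chlorine atom or an amine would compare with methyl on the same aromatic carbon.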